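The source may report more compounds than this note shows. Statements on the series, on what has been measured and on what is new or still open speak of the compounds shown alone.

Compound 3 `FC(F)(F)c1ccccc1OC1CCN(c2ccc(-n3ccnc3)nn2)CC1` gives 4 nM in an assay on microsomes from liver for inhibition of acyl-CoA desaturase 1 (Rattus norvegicus); on this read-out lower numbers stand for stronger inhibition and higher numbers for weaker inhibition; compound 1 `CC(C)c1nnc(-c2ccc(N3CCC(Oc4ccccc4C(F)(F)F)CC3)nn2)s1` gives 8.8 nM; compound 2 `CC(C)(C)c1nnc(-c2ccc(N3CCC(Oc4ccccc4C(F)(F)F)CC3)nn2)o1` gives 980 nM.

Compound 3 holds the lowest number of the three, as a 2.2-fold lower number from compound 1 to compound 3 (0.34 log units; beyond the scatter) and a 250-fold lower number from compound 2 to compound 3 (2.39 log units; beyond the scatter) show. Compound 4 `CC(C)(C)c1nnc(-c2ccc(N3CCC(Oc4ccccc4C(F)(F)F)CC3)nn2)s1` takes the next step: 5-(tert-butyl)-1,3,4-thiadiazol-2-yl in place of 1H-imidazol-1-yl on an aromatic carbon. For the measured compounds named here, two measured steps bear on this. Exchanging the 1H-imidazol-1-yl for the 5-isopropyl-1,3,4-thiadiazol-2-yl cost little, as a 2.2-fold lower number from compound 1 to compound 3 (0.34 log units; beyond the scatter) shows, whereas the 5-(tert-butyl)-1,3,4-oxadiazol-2-yl cost much, as a 250-fold lower number from compound 2 to compound 3 (2.39 log units; beyond the scatter) shows. Compound 4 shares the tert-butyl with compound 2 but the thiadiazole ring with compound 1, and nothing measured separates these two features. A rise in the number is therefore expected for compound 4, of uncertain size, a 6.3-fold higher number from compound 3 to compound 4 (0.80 log units; beyond the scatter). Compound 4 is estimated at 25 nM, within 6 nM to 250 nM.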

Compound 4, half-maximal inhibitory concentration: 710 nM
Compound 4: middle estimate off by 28-fold (1.45 log units), on the low side; measured number above the stated range.
By their numbers in this assay, from the lowest: compound 3; then compound 1; then compounds 4 and 2 (each within the scatter of the next).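

A single methyl separates a low number from a high one on this thiadiazole: turning the isopropyl into tert-butyl gives an 81-fold higher number from compound 1 to compound 4 (1.91 log units; beyond the scatter), and replacing the 1H-imidazol-1-yl with the 5-(tert-butyl)-1,3,4-thiadiazol-2-yl gives a 180-fold higher number from compound 3 to compound 4 (2.25 log units; beyond the scatter). With the tert-butyl kept, exchanging the oxadiazole ring for the thiadiazole ring gives a 1.4-fold lower number from compound 2 to compound 4 (0.14 log units; within the scatter), so this ring change does not recover the lost inhibition. Nothing available explains why one methyl matters so much here.

Still open, as far as these compounds go, is where an ethyl or a cyclopropyl in place of the tert-butyl on the thiadiazole would fall.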